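This account rests on a few compounds, and the source may have more. Where it says the series, first, only, none or still open, it means among the compounds named here.

Compound 1 `O=C1N[C@H]2[C@H](CS[C@H]2CCCCCc2cn(Cc3ccc(C(F)(F)F)cc3)nn2)N1` gives in an assay on isolated protein for inhibition of biotin--protein ligase (Homo sapiens), read by scintillation counting, with a stated time of 10 min (a lower number here means a stronger inhibitor, a higher number a weaker inhibitor), a value of > 16000 nM, which is a limit of the assay.
Compound 2 `O=C1N[C@H]2[C@H](CS[C@H]2CCCCCc2cn(Cc3ccccc3F)nn2)N1` gives in this assay a value of > 16000 nM, again a limit and not a number.

On the numbers shown, compound 2 stands at the limit of the assay, with no value to place it against compound 1 because the limit of > 16000 nM in this assay, at which 2 of the 2 values shown sit, covers both. The step that the two limits leave unreadable from compound 1 to compound 2 therefore cannot be read. Compound 3 `O=C1N[C@H]2[C@H](CS[C@H]2CCCCCc2cn(Cc3ccc(Cl)cc3)nn2)N1` differs from compound 2 by 4-chlorophenyl in place of 2-fluorophenyl on a saturated chain carbon bound to an aromatic nitrogen. Within the data shown here, the only measured step that bears on this change is the one from compound 1 to compound 2, and its size is hidden by the two limits, so no direction and no size can be taken from it. Compound 3 is expected to give a value near the same limit in this assay, estimated at 16000 nM with a range from 5000 nM to 50000 nM, which would mean a step of a number no higher from compound 2 to compound 3 (the limit leaves the size open) that is not expected to reach beyond the scatter.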

Compound 3, inhibition constant: > 16000 nM
Compound 3: no number, only a limit (the forecaster's own chance of this, stated with the estimate: 80%); the middle value sits exactly at the limit.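

Compound 3 gives > 16000 nM in this assay, which is a limit of the assay. No step among compound 1, compound 2 and compound 3 can therefore be read: the limit of > 16000 nM in this assay, at which 3 of the 3 values shown sit.

The compounds shown leave open how strongly each inhibits the enzyme and whether exchanging these benzyl groups changes the result in this assay at all.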